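Cytotoxicity on Vero Cells for Two Nitroimidazole Pairs

A few compounds are considered here, and "the series" means these few. Any claim that something is new, unique, unknown or untested is made for them only; others in the source may bear on it.

Compound 1, `O=[N+]([O-])c1cn2c(n1)OC[C@@H](OCc1ccc(-c3ccc(F)cc3)s1)C2`: > 128000 nM
Compound 2, `O=[N+]([O-])c1cn2c(n1)OC[C@@H](OCc1ccc(-c3ccc(OC(F)(F)F)cc3)s1)C2`: > 128000 nM
Compound 3, `Cn1c(CO[C@@H]2COc3nc([N+](=O)[O-])cn3C2)cnc1-c1ccc(F)cc1`: > 128000 nM

All three measured compounds were tested in an ADME assay on Vero cells (Chlorocebus sabaeus) for cytotoxicity, with a stated time of 72 h; a higher number here means a weaker inhibitor, a lower number a stronger inhibitor. For compound 1 the value > 128000 nM is a limit of the assay rather than a number. For compound 2 the value > 128000 nM is likewise a limit. For compound 3 the value > 128000 nM is also a limit. Compound 2 differs from compound 1 by trifluoromethoxy in place of fluoro on an aromatic carbon. In this assay there is a step that the two limits leave unreadable from compound 1 to compound 2, which rests on (the limit of > 128000 nM in this assay, at which 3 of the 3 values shown sit).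

Compound 4, `Cn1c(CO[C@@H]2COc3nc([N+](=O)[O-])cn3C2)cnc1-c1ccc(OC(F)(F)F)cc1`, has not yet been measured. It differs from compound 3 by trifluoromethoxy in place of fluoro on an aromatic carbon, the same change as that made from compound 1 to compound 2. The difference between the core of compound 1 and the core of compound 3 is not broken down here.

Compound 4 is expected to show a step that the limit leaves unreadable from compound 3 to compound 4, an expected step that is again unlikely to be readable because compound 1 and compound 2 both sit at the limit of > 128000 nM in this assay, at which 3 of the 3 values shown sit. In this assay compound 4 is estimated at 150000 nM, with an expected range from 64000 nM to 300000 nM.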

Compound 4, half-maximal inhibitory concentration: > 128000 nM
Compound 4: only a limit was reported; the forecaster's own chance of this, stated with the estimate: 85%; the middle value is on the limit's open side.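

Within the data shown here, compound 4 gives only a limit, as compound 3 does, so no step between these two compounds can be read in this assay for this pair: the limit of > 128000 nM in this assay, at which 4 of the 4 values shown sit. The compounds shown leave open how far each lies from that limit, and whether trifluoromethoxy in place of fluoro alters cytotoxicity on either core.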